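Ethoxy Addition on Two Related Sulfonamide Cores

A few compounds are considered here, and "the series" means these few. Any claim that something is new, unique, unknown or untested is made for them only; others in the source may bear on it.

Compound 1, `Cc1ccc(S(=O)(=O)Nc2cccc3[nH]nc(Br)c23)cc1`, in a functional assay on A2780 cells (Homo sapiens) for cytotoxicity, read by MTT assay, with a stated time of 72 h (a lower number here means a stronger inhibitor, a higher number a weaker inhibitor), gives 70900 nM.
Compound 2, `CCOc1ccc(NS(=O)(=O)c2ccc(C)cc2)c2c(Br)n[nH]c12`, gives 10500 nM.
Compound 3, `C=CCn1cc2ccc(NS(=O)(=O)c3ccc(C)cc3)cc2n1`, gives 4890 nM.

Compounds 1 and 2 share one core and differ in a single place: ethoxy in place of hydrogen on an aromatic carbon. That change gave a 6.8-fold lower number from compound 1 to compound 2 (0.83 log units; beyond the scatter). Compound 3 carries a different core; how it differs from compound 1 is not broken down here. Among the three measured compounds, compound 3 gives the lowest number, and its step to each of the others is beyond the scatter.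

Compound 4, `C=CCn1cc2ccc(NS(=O)(=O)c3ccc(C)cc3)c(OCC)c2n1`, has not yet been measured. It stands to compound 3 as compound 2 stands to compound 1: ethoxy in place of hydrogen on an aromatic carbon. This is the same kind of change, though not the same: in compound 2 the ethoxy sits para to a large group, while in compound 4 it sits ortho to a large group and ortho to a fused ring. Because the earlier change gave a 6.8-fold lower number from compound 1 to compound 2 (0.83 log units; beyond the scatter), compound 4 is expected to give a lower number than compound 3, with an estimated step of a 2.4-fold lower number from compound 3 to compound 4 (0.39 log units; beyond the scatter), kept smaller than the earlier one since the surroundings of the place differ. Compound 4 is thus estimated at 2000 nM, between 700 nM and 6000 nM.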

Compound 4, half-maximal inhibitory concentration: > 100000 nM
Compound 4 gave a limit, no number (the forecaster's own chance of this, stated with the estimate: 2%); middle value at least 50-fold (1.69 log units) away from the limit.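

In this assay compound 4 gives > 100000 nM as a limit of the assay and not a number. On this core the change of hydrogen to ethoxy on an aromatic carbon gave an at least 20-fold higher number from compound 3 to compound 4 (1.31 log units; beyond the scatter) and so ran opposite to the step on the core of compound 1, which shows that the direction of this change did not carry from one core to the other in this series: the same change on two cores in this assay, a 6.8-fold lower number (0.83 log units; beyond the scatter) from compound 1 to compound 2 and an at least 20-fold higher number (1.31 log units; beyond the scatter) from compound 3 to compound 4, at least 130-fold (2.14 log units) apart, beyond the scatter of two such steps

What this does not show is the full size of the step, since only its lower bound can be read, or whether the core itself or the place of the ethoxy, here ortho to a fused ring and ortho to a large group, decides the direction, since the two pairs differ in both.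

Going by these compounds, it remains open whether methoxy, a longer chain such as propoxy, or an amine at this same place on the core of compound 3 would keep a measurable number or also end at the limit. On these data alone, it is also open whether ethoxy at another place on that core would lower the number, as it did from compound 1 to compound 2.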